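Dropping an Aromatic Methyl Across Two Inhibitor Cores

A few compounds are considered here, and "the series" means these few. Any claim that something is new, unique, unknown or untested is made for them only; others in the source may bear on it.

The study compares three measured compounds and one that awaits measurement in an assay on membranes from brain for binding affinity to neutral cholesterol ester hydrolase 1 (Mus musculus), read by fluorescence, with stated times of 1 h and 30 min; a lower number here means a stronger inhibitor, a higher number a weaker inhibitor. Compound 1 `Cc1cnn(C(=O)NCc2ccc(OCc3ccccc3)cc2)c1` carries a 4-methyl-1H-pyrazol-1-yl group on its core. In this assay compound 1 reaches only the limit, giving > 100000 nM. Compound 2 `O=C(NCc1ccc(OCc2ccccc2)cc1)n1cccn1` differs from compound 1 by hydrogen in place of methyl on an aromatic carbon. In this assay compound 2 likewise stops at the limit, giving > 100000 nM. The step that the two limits leave unreadable from compound 1 to compound 2 therefore cannot be read in size. Compound 3 `Cc1cnn(C(=O)N2CCN(C(c3ccc(OCc4ccccc4)cc3)c3ccc(OCc4ccccc4)cc3)CC2)c1` is built on another core; how the core of compound 3 differs from the core of compound 1 is not broken down here. In this assay compound 3 also reaches only the limit, giving > 100000 nM. Compound 4 `O=C(N1CCN(C(c2ccc(OCc3ccccc3)cc2)c2ccc(OCc3ccccc3)cc2)CC1)n1cccn1` is related to compound 3 by hydrogen in place of methyl on an aromatic carbon, the same change as that between compound 1 and compound 2. The step that the limit leaves unreadable from compound 3 to compound 4 is expected to remain unreadable in the same way as the earlier one, because of the limit of > 100000 nM in this assay, at which 3 of the 3 values shown sit. Compound 4 is accordingly estimated at 200000 nM, with a likely span from 100000 nM to 1000000 nM.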

Compound 4, half-maximal inhibitory concentration: > 100000 nM
Compound 4: a limit, no number (the forecaster's own chance of this, stated with the estimate: 90%); the middle value does not contradict the limit.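

No new step can be read: the step from compound 3 to compound 4 stays as unreadable as the one from compound 1 to compound 2, because every result is only a limit: the limit of > 100000 nM in this assay, at which 4 of the 4 values shown sit.

The compounds shown leave open whether the change from 4-methyl-1H-pyrazol-1-yl to 1H-pyrazol-1-yl alters inhibition on either core.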